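This account rests on a few compounds, and the source may have more. Where it says the series, first, only, none or still open, it means among the compounds named here.

Among the compounds with values here, compound 2 `COc1cc(-c2nn(-c3cccc(NC(=O)Nc4ccc(Cl)c(Cl)c4)c3)cc2-c2ccncc2)ccc1Cl` holds the lower of the two numbers measured so far in a functional assay on OVCAR-8 cells (Homo sapiens) for inhibition, read by sulforhodamine B assay, with a stated time of 48 h; on this read-out lower numbers stand for stronger inhibition of growth and higher numbers for weaker inhibition of growth: compound 2 gives 931 nM, while compound 1 `COc1cc(-c2nn(-c3cccc(NC(=O)c4cccc(C(F)(F)F)c4)c3)cc2-c2ccncc2)ccc1Cl` gives 2000 nM. Within the data shown here, the only measured step, a 2.1-fold lower number from compound 1 to compound 2 (0.33 log units; beyond the scatter), alters two things at once, the group on the carbonyl carbon and the aryl ring within it, so its contributions cannot be separated. Compound 3 `COc1cc(-c2nn(-c3cccc(NC(=O)Nc4cccc(C(F)(F)F)c4)c3)cc2-c2ccncc2)ccc1Cl` keeps the amide-type nitrogen of compound 2 and differs from it in one place: 3-(trifluoromethyl)phenyl in place of 3,4-dichlorophenyl on an amide-type nitrogen. Among the measured compounds shown here, the aryl group that enters is the one carried by compound 1, so the measured step bears on this change only indirectly, and the direction of the aryl exchange by itself is not resolved by the data. The change is therefore expected to move the number only modestly, a 1.4-fold higher number from compound 2 to compound 3 (0.14 log units; within the scatter). Compound 3 is estimated at 1300 nM, within a range from 500 nM to 3500 nM.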

Compound 3, concentration for 50% growth inhibition: 739 nM
For compound 3 the middle estimate is 1.8-fold (0.25 log units) above the measured one; low and high end bracket the measured number.
By their numbers in this assay, from the lowest: compounds 3 and 2 (each within the scatter of the next); then compound 1.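

In this assay, exchanging 3,4-dichlorophenyl for 3-(trifluoromethyl)phenyl on the amide-type nitrogen gives a 1.3-fold lower number from compound 2 to compound 3 (0.10 log units; within the scatter) and so separates neither aryl group from the other at this position. With the 3-(trifluoromethyl)phenyl group held fixed, adding the amide-type nitrogen on the carbonyl carbon gives a 2.7-fold lower number from compound 1 to compound 3 (0.43 log units; beyond the scatter) and isolates a modest change that the earlier step had mixed with the aryl exchange. Nothing measured here gives a reason for either step.

The compounds shown leave open whether the 3,4-dichlorophenyl group would respond in the same way to the amide-type nitrogen, as only the 3-(trifluoromethyl)phenyl pair is available. They also leave open how an unsubstituted phenyl on that nitrogen, or a methyl group on the nitrogen itself, would compare.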